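Swapping a Benzodioxin for an Indole on the Triazole

The compounds below may be only part of what the source reports. "The series", "measured", "known", "first", "only" and "open" are said of these compounds alone.

Compound 1 `O[C@H](COCCOC[C@@H](O)Cc1cn(-c2ccc3c(c2)OCCO3)nn1)Cc1ccc(-c2ccccc2)cc1`: 16500 nM
Compound 2 `COC1=C(OC)C(=O)C(CCCCCCCCCCCCCCCn2cc(C[C@H](O)COCCOC[C@@H](O)Cc3ccc(-c4ccccc4)cc3)nn2)=C(C)C1=O`: 1500 nM
Compound 3 `COC1=C(OC)C(=O)C(CCCCCCn2cc(C[C@H](O)COCCOC[C@@H](O)Cc3ccc(-c4ccccc4)cc3)nn2)=C(C)C1=O`: 5000 nM

In a functional assay on HCT-116 cells (Homo sapiens) for inhibition, read by MTT assay, with a stated time of 72 h (on this read-out higher numbers stand for weaker inhibition of growth and lower numbers for stronger inhibition of growth), compound 1 gives 16500 nM, the highest of the three numbers, and so the weakest growth inhibition shown here; compound 3 gives 5000 nM and compound 2 gives 1500 nM, both well below it. Compound 4 `O[C@H](COCCOC[C@@H](O)Cc1cn(-c2ccc3[nH]ccc3c2)nn1)Cc1ccc(-c2ccccc2)cc1` keeps the whole chain and core of compound 1 and changes only one end: 1H-indol-5-yl in place of 2,3-dihydro-1,4-benzodioxin-6-yl on an aromatic nitrogen. For the measured compounds named here, no measured pair shows what such a swap on the triazole does, so the expected step from compound 1 a 1.1-fold lower number from compound 1 to compound 4 (0.04 log units; within the scatter) is estimated to stay within the usual scatter, in no clear direction. Compound 4 is therefore expected to give about 15000 nM in this assay, with a likely range from 6000 nM to 40000 nM.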

Compound 4, concentration for 50% growth inhibition: 15500 nM
The estimate for compound 4 lay 1.0-fold (0.01 log units) below the measured number; measured number inside the range.
By their numbers in this assay, from the lowest: compound 2; then compound 3; then compounds 4 and 1 (each within the scatter of the next).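

In this assay the group 1H-indol-5-yl in place of 2,3-dihydro-1,4-benzodioxin-6-yl on an aromatic nitrogen gives a 1.1-fold lower number from compound 1 to compound 4 (0.03 log units; within the scatter) and the two compounds cannot be told apart. At this position, then, two hydrogen-bond acceptors and a non-aromatic ring can give way to a hydrogen-bond donor and a five-membered aromatic ring with no clear difference in growth inhibition. No supporting measurement bears on this result. On these data alone, whether a carboxylic acid or an amine at this place would read differently remains open. So does whether the two groups would also read alike on another core.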